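The source may hold more compounds than are shown below. What is called first, only, known or untested is meant among the compounds shown, and "the series" means these compounds.

Working notes on a functional assay on MDA-MB-231 cells (Homo sapiens) for cytotoxicity, read by MTT assay, with a stated time of 48 h; on this read-out higher numbers stand for an effect only at larger amounts of compound and lower numbers for an effect already at smaller amounts. Compound 1 `CO[C@H]1O[C@H](COc2ccc(OC3CCCCC3)cc2)[C@@H](O)[C@H](O)[C@H]1Oc1ccc(OC2CCCCC2)cc1` gives 20000 nM and compound 2 `CO[C@@H]1O[C@H](COc2ccc(OC3CCCCC3)cc2)[C@@H](O)[C@H](O)[C@H]1Oc1ccc(OC2CCCCC2)cc1` gives 26000 nM. Among the compounds with values here, the step of a 1.3-fold higher number from compound 1 to compound 2 (0.11 log units; within the scatter) lies within the scatter; the only evidence behind it is the fact that compounds 1 and 2 differ only in the configuration as drawn, so no order between the two compounds is claimed. Compound 3 `CO[C@H]1O[C@H](COc2ccccc2)[C@@H](O)[C@H](O)[C@H]1Oc1ccc(OC2CCCCC2)cc1` is recorded in this assay as "not determined" (no result reported), so it carries no number. Compound 2 therefore stands with the highest of the two numbers, its nearest neighbour being compound 1, which sits within the scatter of it.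

Compound 4 `CO[C@@H]1O[C@H](COc2ccc(OC3CCCCC3)cc2)[C@@H](O)[C@H](O)[C@H]1Oc1ccc(C(C)C)cc1` differs from compound 2 in isopropyl in place of cyclohexyloxy on an aromatic carbon. Within the data shown here, no measured step bears on this change: the single step on record concerns configuration alone and says nothing about isopropyl in place of cyclohexyloxy. The anchor for compound 4 is therefore compound 2 at 26000 nM. For compound 4 the step of no change at the digits printed from compound 2 to compound 4 (within the scatter) is expected to stay within the scatter, with a wide margin for either direction. Compound 4 is estimated at 26000 nM, in the range 8000 nM to 80000 nM.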

Compound 4, half-maximal effective concentration: 35000 nM
Compound 4: middle estimate off by 1.3-fold (0.13 log units), on the low side; measured number inside the range.
By their numbers in this assay, from the lowest: compounds 1, 2 and 4 (each within the scatter of the next).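

In this assay, isopropyl in place of cyclohexyloxy on an aromatic carbon, para to a large group, gives a 1.3-fold higher number from compound 2 to compound 4 (0.13 log units; within the scatter). Within the data shown here, this is the first step that concerns a group rather than configuration: at this place, the six-membered carbon ring and the oxygen of cyclohexyloxy can give way to isopropyl, which has no ring and no hydrogen-bond acceptor, and the two numbers still cannot be told apart. Nothing on record bears on this step.

The compounds shown leave open whether an amine or a carboxylic acid at this place would move the number beyond the scatter. They also leave open whether isopropyl would give a similar result in the configuration of compound 1, or in place of the second cyclohexyloxy.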